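This account rests on a few compounds, and the source may have more. Where it says the series, first, only, none or still open, it means among the compounds named here.

Measured compounds:
- compound 1 `COc1cccc(-c2cc(-c3ccc([N+](=O)[O-])cc3)[nH]n2)c1`: 11200 nM
- compound 2 `COc1ccc(-c2cc(-c3ccccc3)n[nH]2)cc1`: 10400 nM
- compound 3 `COc1ccc(-c2cc(-c3ccccc3-c3ccccc3)n[nH]2)cc1`: 730 nM

In a functional assay on NCI-H460 cells (Homo sapiens) for inhibition, read by MTT assay, with a stated time of 48 h (on this read-out higher numbers stand for weaker inhibition of growth and lower numbers for stronger inhibition of growth), compound 3 gives the lowest number of the three measured compounds. Its nearest neighbour is compound 2, and a 14-fold lower number from compound 2 to compound 3 (1.15 log units; beyond the scatter), a step that lies beyond the scatter. Compound 1 stands further away still.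

Compound 4 `COc1cccc(-c2cc(-c3ccccc3-c3ccccc3)n[nH]2)c1` is not yet measured. It keeps the biphenyl group of compound 3 and differs only in 3-methoxyphenyl in place of 4-methoxyphenyl on an aromatic carbon. Among the measured compounds shown here, no measured step addresses this change directly: compound 1 also carries a 3-methoxyphenyl group, but it differs from compound 3 in more than one place, so its value and that of compound 3 can only be set side by side, not read as a step. For the measured compounds named here, the one measured step, from compound 2 to compound 3, concerns the biphenyl group, which compound 4 retains.

With nothing bearing on the methoxyphenyl change itself, the expected step of a 1.4-fold higher number from compound 3 to compound 4 (0.14 log units; within the scatter) is small, with a wide range allowed either way. Compound 4 is estimated at 1000 nM, between 350 nM and 3000 nM.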

Compound 4, concentration for 50% growth inhibition: 8700 nM
Compound 4: the middle estimate sits 8.7-fold (0.94 log units) below what was measured, outside the stated range (above it).
By their numbers in this assay, from the lowest: compound 3; then compounds 4, 2 and 1 (each within the scatter of the next).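

In this assay, the step of a 12-fold higher number from compound 3 to compound 4 (1.08 log units; beyond the scatter) comes from 3-methoxyphenyl in place of 4-methoxyphenyl alone, with the same atoms and the biphenyl group kept, so this aromatic carbon of the shared core is sensitive to where the methoxy group sits on its phenyl ring. The low number of compound 3 at 730 nM therefore does not follow from the biphenyl group alone, and the earlier step of a 14-fold lower number from compound 2 to compound 3 (1.15 log units; beyond the scatter), measured with 4-methoxyphenyl in place, cannot be assumed to carry over to 3-methoxyphenyl compounds. No measurement at hand accounts for the size of this step.

The compounds shown leave open whether a hydroxyl group or an amine on that phenyl ring, in place of the methoxy group, would keep the number of compound 3 low. They also leave open how a longer alkoxy chain at the 4-position of that ring would read in this assay.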